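Replacing the aryl amide cap: notes toward compound 4

The source may report more compounds than this note shows. Statements on the series, on what has been measured and on what is new or still open speak of the compounds shown alone.

Measured so far in an assay on isolated protein for inhibition of Rho-associated protein kinase 1 (Homo sapiens), read by scintillation counting, radiometric assay and 33P incorporation, with a stated time of 40 min, in the presence of a further agent that is not named here; on this read-out lower numbers stand for stronger inhibition and higher numbers for weaker inhibition:
compound 1 `CCc1ccc(C(=O)Nc2cccc(NC(=O)COc3ccc4c(=O)ccoc4c3)c2)cc1` gives 235 nM
compound 2 `CC(C)(C)c1ccc(C(=O)Nc2cccc(NC(=O)COc3ccc4c(=O)ccoc4c3)c2)cc1` gives 165 nM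
compound 3 `CCOc1ccc(C(=O)Nc2cccc(NC(=O)COc3ccc4c(=O)ccoc4c3)c2)cc1` gives 17 nM

Compound 3 stands lowest of the three numbers in this assay; its nearest neighbour is compound 2, a 9.7-fold lower number from compound 2 to compound 3 (0.99 log units; beyond the scatter), and the furthest is compound 1, a 14-fold lower number from compound 1 to compound 3 (1.14 log units; beyond the scatter). Between compounds 1 and 2 the change was a 1.4-fold lower number from compound 1 to compound 2 (0.15 log units; within the scatter), so the two alkyl-capped compounds sit together and the ethoxy cap alone sets compound 3 apart.

Compound 4 `Cc1cc(C(=O)Nc2cccc(NC(=O)COc3ccc4c(=O)ccoc4c3)c2)no1` is not yet measured. The change is 5-methyl-1,2-oxazol-3-yl in place of 4-ethoxyphenyl on a carbonyl carbon. Among the measured compounds shown here, none of the measured steps covers this exchange: all three vary only the group on the aromatic carbon of the 4-ethoxyphenyl cap, and compound 4 removes that cap altogether, including the ethoxy that carried the whole gain from compound 1 and compound 2 to compound 3. For the measured compounds named here, the steps that bear on it therefore speak only indirectly: without the ethoxy, the number returned toward the region of compound 1 and compound 2, and a new five-membered ring with two hetero atoms has no precedent here.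

The expectation for compound 4 is a higher number, estimated at a 15-fold higher number from compound 3 to compound 4 (1.17 log units; beyond the scatter), with a wide range given the lack of a matching step. The estimate for compound 4 is 250 nM, expected between 60 nM and 1200 nM.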

Compound 4, half-maximal inhibitory concentration: 68 nM
Compound 4: middle estimate off by 3.7-fold (0.57 log units), on the high side, within the range that was stated.
By their numbers in this assay, from the lowest: compound 3; then compound 4; then compounds 2 and 1 (each within the scatter of the next).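

In this assay, the cap on the carbonyl carbon does not depend on a six-membered aromatic ring of carbon only: 5-methyl-1,2-oxazol-3-yl, a five-membered aromatic ring with 2 hetero atoms, in place of 4-ethoxyphenyl gives a 4.0-fold higher number from compound 3 to compound 4 (0.60 log units; beyond the scatter), a smaller loss than the gap that separates the alkyl-capped compounds from the ethoxy cap. Among the compounds shown here, the same exchange read against those alkyl caps gives a 2.4-fold lower number from compound 2 to compound 4 (0.38 log units; beyond the scatter) and a 3.5-fold lower number from compound 1 to compound 4 (0.54 log units; beyond the scatter), so the ethoxy on a phenyl ring is not the only route to a number lower than those of the 4-ethylphenyl and 4-(tert-butyl)phenyl caps, although compound 3 still holds the lowest number. Nothing measured here accounts for any of these differences.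

The compounds shown leave open what the methyl on the new ring contributes, as against a bare 1,2-oxazol-3-yl cap or an ethyl in place of that methyl. They also leave open whether an ethoxy in place of that methyl would repeat on this ring the gain seen on the phenyl cap in a 14-fold lower number from compound 1 to compound 3 (1.14 log units; beyond the scatter).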